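This account rests on a few compounds, and the source may have more. Where it says the series, first, only, none or still open, it means among the compounds named here.

Series notes on the step from compound 1 to compound 4. Compound 1 `C=C[C@@](C)(/C=C/c1ccc(OC)cc1)CCC=C(C)C` is the starting point. In a functional assay on NALM-6 cells (Homo sapiens) for cytotoxicity, with a stated time of 72 h (on this read-out higher numbers stand for an effect only at larger amounts of compound and lower numbers for an effect already at smaller amounts), compound 1 gives > 43400 nM, which is a limit of the assay and not a number. Compound 2 `CC(C)=CCC[C@@](C)(/C=C/c1ccc(C)cc1)/C=C/c1ccc(O)cc1` is a second member of the set. In this assay compound 2 gives > 43400 nM, again a limit. Compound 3 `C=C[C@@](C)(/C=C/c1ccc(Nc2c(F)cc(F)cc2F)cc1)CCC=C(C)C` completes the measured set. In this assay compound 3 gives > 43400 nM, likewise a limit. Within the data shown here, compound 1 therefore stands together with every other measured member at the limit of > 43400 nM in this assay, at which 3 of the 3 values shown sit; no number and no step between measured compounds is available, and nothing separates the three. Compound 4 `C=C[C@@](C)(/C=C/c1ccc(-c2ccc(F)cc2)cc1)CCC=C(C)C` is the compound still to be measured; it differs from compound 1 by 4-fluorophenyl in place of methoxy on an aromatic carbon. With every measured value sitting at the limit, no direction for the step is expected beyond the scatter, and a further limit is the most likely outcome. The expected step is a step that the limit leaves unreadable from compound 1 to compound 4. Compound 4 is estimated to give 50000 nM in this assay, within a range from 15000 nM to 200000 nM.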

Compound 4, half-maximal effective concentration: > 43400 nM
Compound 4: no number, only a limit; the forecaster's own chance of this, stated with the estimate: 75%; the middle value does not contradict the limit.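

In this assay compound 4 gives > 43400 nM, a limit of the assay and not a number. No step can be read between compound 1 and compound 4. The compounds shown leave open whether any variation on the shared core gives a readable value in this assay.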